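A few compounds are considered here, and "the series" means these few. Any claim that something is new, unique, unknown or untested is made for them only; others in the source may bear on it.

Compound 1 `O=C(CCCCCCc1ccccc1)CC(=O)N[C@H]1CCOC1=O` and compound 3 `O=C(CCCCCCCc1ccccc1)CC(=O)N[C@H]1CCOC1=O` share a core and differ in one place. In a functional assay on PC-3 cells (Homo sapiens) for cytotoxicity, read by sulforhodamine B assay, with a stated time of 5 days (a higher number here means a weaker inhibitor, a lower number a stronger inhibitor), compound 1 gives 9000 nM, while compound 3 gives 2000 nM. The change benzyl in place of phenyl on a saturated chain carbon, six bonds along the chain from a carbonyl carbon produced a 4.5-fold lower number from compound 1 to compound 3 (0.65 log units; beyond the scatter). Compound 2 `O=C(CCCCCCCCCCc1ccccc1)N[C@H]1CCOC1=O` rests on a different core; the difference between the two cores is not broken down here. In this assay compound 2 gives 66000 nM, the highest of the three numbers. Compound 4 `O=C(CCCCCCCCCCCc1ccccc1)N[C@H]1CCOC1=O` is compound 2 carrying the same kind of change, (benzyl in place of phenyl on a saturated chain carbon, ten or more bonds along the chain from a carbonyl carbon), though at a different place along the chain from that of the change between compound 1 and compound 3. Because the same kind of change gave a 4.5-fold lower number from compound 1 to compound 3 (0.65 log units; beyond the scatter), compound 4 is expected to show a lower number than compound 2, with the different place leaving the size less certain. For compound 4 the estimated step in this assay is a 2.6-fold lower number from compound 2 to compound 4 (0.42 log units; beyond the scatter). Compound 4 is therefore estimated at 25000 nM, within 8000 nM to 66000 nM.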

Compound 4, half-maximal inhibitory concentration: > 100000 nM
Compound 4 gave a limit, no number; the forecaster's own chance of this, stated with the estimate: 5%; middle value at least 4.0-fold (0.60 log units) from the limit.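

Compound 4 gives > 100000 nM in this assay, which is a limit of the assay and not a number. As far as these compounds go, the step therefore reads as an at least 1.5-fold higher number from compound 2 to compound 4 (0.18 log units; that floor lies within the scatter), and its true size stays unknown. With one pair on each core, at different places along the chain, the result does not show whether the core or the place matters more, but the change did not carry over unchanged from one core to the other: the same change on two cores in this assay, a 4.5-fold lower number (0.65 log units; beyond the scatter) from compound 1 to compound 3 and an at least 1.5-fold higher number (0.18 log units; that floor lies within the scatter) from compound 2 to compound 4, at least 6.8-fold (0.83 log units) apart, beyond the scatter of two such steps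

The compounds shown leave open what a phenethyl group or a longer chain would do on each core. They also leave open whether an amine or a carboxylic acid in place of the phenyl group would give a measurable number on the core of compound 2.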